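The compounds below may be only part of what the source reports. "The series", "measured", "known", "first", "only" and "open" are said of these compounds alone.

Within the data shown here, in a functional assay on MCF7 cells (Homo sapiens) for cytotoxicity, read by MTT assay and propidium iodide staining, with a stated time of 24 h (on this read-out lower numbers stand for stronger inhibition and higher numbers for weaker inhibition), compound 3 `O=C(CSc1nnc(-c2ccncc2)o1)c1ccc(Br)cc1` gives 4230 nM and holds the highest of the three numbers so far. Compound 2 `Cc1ccc(-c2nnc(SCC(=O)c3ccc(Br)cc3)o2)c(O)c1` gives 2070 nM and sits nearest to it, while compound 1 `Nc1cc(-c2nnc(SCC(=O)c3ccccc3)o2)ccn1` gives 140 nM and sits furthest below it.

The change from compound 3 to compound 4 `Nc1cc(-c2nnc(SCC(=O)c3ccc(Br)cc3)o2)ccn1` reads amino in place of hydrogen on an aromatic carbon and amounts to amino in place of hydrogen on an aromatic carbon, next to the ring nitrogen and meta to a large group, so that pyridin-4-yl becomes 2-aminopyridin-4-yl.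

Among the measured compounds shown here, the one measured step, a 2.0-fold higher number from compound 2 to compound 3 (0.31 log units; beyond the scatter) with pyridin-4-yl in place of 2-hydroxy-4-methylphenyl, is modest. It shows that exchanging this aromatic group can move the number, but it does not test the amino group. For the measured compounds named here, compound 1 already carries 2-aminopyridin-4-yl and stands at 140 nM as the lowest of the three numbers, yet it is not a one-place neighbour of compound 3, so no measured step isolates the amino group.

A move to a lower number is therefore expected, with the size estimated as a 5.3-fold lower number from compound 3 to compound 4 (0.72 log units; beyond the scatter) and so larger than that modest step. Compound 4 is expected at 800 nM with an estimated range from 150 nM to 3500 nM in this assay once measured.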

Compound 4, half-maximal inhibitory concentration: 200 nM
Compound 4: the middle estimate sits 4.0-fold (0.60 log units) above what was measured, and the stated range covers the measured number.
By their numbers in this assay, from the lowest: compounds 1 and 4 (each within the scatter of the next); then compound 2; then compound 3.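

The amino group now has a step of its own in this assay: with amino in place of hydrogen, next to the ring nitrogen and meta to a large group, the series shows a 21-fold lower number from compound 3 to compound 4 (1.33 log units; beyond the scatter) and this is a large change, whereas the earlier exchange of aromatic groups gave only a 2.0-fold higher number from compound 2 to compound 3 (0.31 log units; beyond the scatter) as a modest one. The amino group also reverses the direction of that exchange, since 2-aminopyridin-4-yl in place of 2-hydroxy-4-methylphenyl gives a 10-fold lower number from compound 2 to compound 4 (1.01 log units; beyond the scatter) while pyridin-4-yl moved the number the other way. Bromo in place of hydrogen gives a 1.4-fold higher number from compound 1 to compound 4 (0.15 log units; within the scatter) and stays within the scatter, so with 2-aminopyridin-4-yl present, the two compounds cannot be told apart here.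

The compounds shown leave open whether the amino hydrogens are needed, which methylamino, dimethylamino or acetamido at the same place would test, and whether bromo is equally silent on the plain pyridin-4-yl compounds. Among these compounds, nothing available explains why the amino group moves the number so far.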